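Trimming the chain end of compound 3 toward compound 4

The source may hold more compounds than are shown below. What is called first, only, known or untested is meant among the compounds shown, and "the series" means these compounds.

Within the data shown here, compound 3 `c1ccc2c(c1)CN[C@@H](CN(CCCCNC1CCNCC1)[C@H]1CCCc3cccnc31)C2` is one of three compounds measured in a functional assay on cells for agonist activity at C-X-C chemokine receptor type 4 (Homo sapiens), read by fluorescence and calcium flux, with a stated time of 90 s; on this read-out higher numbers stand for an effect only at larger amounts of compound and lower numbers for an effect already at smaller amounts. In this assay compound 3 reports only a limit, > 30000 nM. Compound 1 `c1ccc(CN(CCCCN(C[C@H]2Cc3ccccc3CN2)[C@H]2CCCc3cccnc32)Cc2ccccc2)cc1` likewise reports a limit in this assay, > 30000 nM. Compound 2 `O=S1(=O)CCC(CNCCCCN(C[C@H]2Cc3ccccc3CN2)[C@H]2CCCc3cccnc32)CC1` gives a limit as well, > 30000 nM. So the limit of > 30000 nM in this assay, at which 3 of the 3 values shown sit: compound 3 stands level with the other two, and no number separates any of them.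

Compound 4 `CC(C)(CN)CCN(C[C@H]1Cc2ccccc2CN1)[C@H]1CCCc2cccnc21` differs from compound 3 by 1-(aminomethyl)-1-methylethyl in place of 2-((piperidin-4-yl)amino)ethyl on a saturated chain carbon, two bonds along the chain from an amine nitrogen. Among the measured compounds shown here, the one measured step that touches this part of the molecule, a step that the two limits leave unreadable from compound 2 to compound 3, has both of its ends at the limit and cannot be read. It therefore gives no direction for the change from compound 3 to compound 4, and the shared core with a shortened chain end has no measured precedent among these compounds. With three limits and nothing else to go on, the expected step of a number no higher from compound 3 to compound 4 (the limit leaves the size open) is none beyond the scatter, and compound 4 is expected to return a limit as well. The estimate for compound 4 in this assay is 30000 nM, with a range from 10000 nM to 100000 nM, and the read-out is expected again to report only a limit rather than a number.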

Compound 4, half-maximal effective concentration: > 30000 nM
Compound 4 was reported as a limit; the forecaster's own chance of this, stated with the estimate: 80%; the middle value sits exactly at the limit.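

In this assay compound 4 gives > 30000 nM as a limit and not a number. The steps from compound 2 and from compound 3 to compound 4 cannot be read, and the series offers only this: the limit of > 30000 nM in this assay, at which 4 of the 4 values shown sit. The compounds shown leave open which change, if any, would give a measurable value.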